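The compounds below may be only part of what the source reports. "The series", "measured", "known", "first", "only" and "open" are said of these compounds alone.

Working notes on the series. The shared core of compound 1 `OCCCNCc1nc2c(OCC3CCCCC3)cccc2[nH]1` carries an amine nitrogen whose substituent is varied; compound 2 `OCCCCCNCc1nc2c(OCC3CCCCC3)cccc2[nH]1` and compound 3 `CC(C)(CO)NCc1nc2c(OCC3CCCCC3)cccc2[nH]1` differ from it only there. In an assay on cells for inhibition of interleukin-5 receptor subunit alpha (Mus musculus), read by WST assay, with a stated time of 48 h, tested at 30 uM, in the presence of a further agent that is not named here (on this read-out lower numbers stand for less inhibition and higher numbers for more inhibition at the one concentration tested (going by the name of the read-out)), compound 1 gives 52.7%, compound 2 gives 23.7%, and compound 3 gives 54.7%. Compound 3 holds the highest of the three numbers, but its gap to compound 1 lies within the scatter, so no order between those two can be read; its gap to compound 2 lies beyond the scatter.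

The measured steps are a number 29 percentage points lower from compound 1 to compound 2 (beyond the scatter), a number 2 percentage points higher from compound 1 to compound 3 (within the scatter) and a number 31 percentage points higher from compound 2 to compound 3 (beyond the scatter). Each step keeps a hydroxy-bearing saturated substituent on the amine nitrogen and only changes its length or branching.

Compound 4 `COc1ccc(NCc2nc3c(OCC4CCCCC4)cccc3[nH]2)cc1` departs from that set: 4-methoxyphenyl in place of 1-(hydroxymethyl)-1-methylethyl on an amine nitrogen. Going by the values given here, no measured step replaces the saturated substituent with an aromatic ring, nor removes the hydrogen-bond donor, so the three steps above bear on it only loosely. The step from compound 1 to compound 2 shows that an unfavourable change at this position can cost a modest amount; the step from compound 2 to compound 3 shows the same size in the other direction. Because of a number 29 percentage points lower from compound 1 to compound 2 (beyond the scatter) a change of that order, downward, is expected, with wide uncertainty: compound 4 is estimated at 40%, range 15% to 65%, corresponding to an expected step of a number 14.7 percentage points lower from compound 3 to compound 4 (beyond the scatter).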

Compound 4, a percentage reported as inhibition, at one concentration (the size of the read-out at that concentration, not a potency): 20.3%
Estimate against measurement, compound 4: 19.7 percentage points above; measured number inside the range.
By their numbers in this assay, from the lowest: compounds 4 and 2 (each within the scatter of the next); then compounds 1 and 3 (each within the scatter of the next).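

In this assay, the 4-methoxyphenyl group gives the first view of an aromatic ring on this amine nitrogen, in a substituent without a hydrogen-bond donor, and the change from either of the two higher compounds is large: a number 34.4 percentage points lower from compound 3 to compound 4 (beyond the scatter) and a number 32.4 percentage points lower from compound 1 to compound 4 (beyond the scatter). The other comparison, a number 3.4 percentage points lower from compound 2 to compound 4 (within the scatter), allows no order to be read, so the low level of this series is shared by a substituent with a ring and no hydrogen-bond donor and by the unbranched 5-hydroxypentyl chain, which has no ring and keeps its hydroxy group. The hydroxy group alone therefore does not hold the number up at this position, and nothing measured on hand explains the differences.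

The compounds shown leave open whether the lower number of compound 4 goes with the aromatic ring or with the missing hydroxy group, and the two are changed together here. A 4-hydroxyphenyl or a cyclohexyl group on the same amine nitrogen would separate them, and a read-out at more than the one concentration would show whether these differences hold as differences in potency.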